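This account rests on a few compounds, and the source may have more. Where it says the series, first, only, none or still open, it means among the compounds named here.

Measured so far in a functional assay on ECa-109 cells (Homo sapiens) for inhibition, read by MTT assay, with a stated time of 72 h; a higher number here means a weaker inhibitor, a lower number a stronger inhibitor:

Compound 1 `C#CCSc1nc(Nc2ccc(Cl)cc2)c(C#N)c(-c2ccccc2)n1` gives > 128000 nM, a limit of the assay rather than a number.
Compound 2 `N#Cc1c(Nc2ccccc2Cl)nc(SCc2cn(Cc3ccccc3Cl)nn2)nc1-c1ccccc1` gives 28500 nM.
Compound 3 `COc1ccccc1Nc1nc(SCc2cn(Cc3ccccc3Cl)nn2)nc(-c2ccccc2)c1C#N` gives 9670 nM.

Compound 3 stands lowest of the two numbers shown in this assay; its nearest neighbour is compound 2, and the step of a 2.9-fold lower number from compound 2 to compound 3 (0.47 log units; beyond the scatter) lies beyond the scatter. Compound 1 sits at the limit of > 128000 nM in this assay, at which 1 of the 3 values shown sits, and gives no number to compare.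

Compound 4 `N#Cc1c(Nc2ccc(F)cc2)nc(SCc2cn(Cc3ccccc3Cl)nn2)nc1-c1ccccc1` has not yet been measured in this assay. It differs from compound 3 in one place: 4-fluorophenyl in place of 2-methoxyphenyl on a nitrogen on an aromatic ring. Within the data shown here, the only measured step that bears on this change is a 2.9-fold lower number from compound 2 to compound 3 (0.47 log units; beyond the scatter), which also alters the group on that nitrogen, but it swaps chloro for methoxy at one position, whereas the change to compound 4 swaps a 2-methoxyphenyl for a 4-fluorophenyl. Compound 1 carries a 4-chlorophenyl on the nitrogen, yet its thioether differs, so its limit cannot be read as a step. Given that the removal of methoxy reverses the one change that lowered the number, compound 4 is expected to give a modestly higher number, an estimated step of a 2.1-fold higher number from compound 3 to compound 4 (0.32 log units; beyond the scatter). Compound 4 is therefore estimated at 20000 nM, with a range from 6000 nM to 70000 nM.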

Compound 4, half-maximal inhibitory concentration: 25800 nM
Beside the measured number, compound 4's estimate is 1.3-fold (0.11 log units) below it; measured number inside the range.
By their numbers in this assay, from the lowest: compound 3; then compounds 4 and 2 (each within the scatter of the next). At a limit, above all of these: compound 1.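

Read in this assay, the change gives a 2.7-fold higher number from compound 3 to compound 4 (0.43 log units; beyond the scatter), so a 4-fluorophenyl on this nitrogen does not hold the lower number seen with the 2-methoxyphenyl. The comparison with the chlorinated analogue gives a 1.1-fold lower number from compound 2 to compound 4 (0.04 log units; within the scatter), which shows that 4-fluorophenyl and 2-chlorophenyl read alike here, although they differ in both the halogen and where it sits on the ring; among these three compounds, which differ only in this group, compound 3 alone stands apart. The compounds shown offer no measurement that explains why the 2-methoxyphenyl stands apart from the two halogenated phenyl groups.

It remains open whether the lower number belongs to methoxy itself or to its place on the ring, since a 4-methoxyphenyl and a 2-fluorophenyl are not among the compounds shown. Also open, as far as these compounds go, is how other groups on this phenyl ring, such as a hydroxyl, an amine or a longer ether chain like ethoxy, would read in this assay.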